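A few compounds are considered here, and "the series" means these few. Any claim that something is new, unique, unknown or untested is made for them only; others in the source may bear on it.

Measured compounds:
Compound 1, `Cc1cccc(C)c1NC(=O)CC(=O)Oc1c(C(C)C)cccc1C(C)C`, gives 210 nM.
Compound 2, `CC(C)c1cccc(C(C)C)c1NC(=O)CC(=O)Oc1c(-c2ccccc2)cccc1-c1ccccc1`, gives 67 nM.
Compound 3, `CCCCCCCCCCC(C)OC(=O)CC(=O)Nc1c(C(C)C)cccc1C(C)C`, gives 6 nM.

All three were tested in an assay on microsomes from intestine for inhibition of acyl-CoA:cholesterol acyltransferase (Oryctolagus cuniculus); on this read-out higher numbers stand for weaker inhibition and lower numbers for stronger inhibition. Compound 1 stands at the highest number of the three and is therefore the weakest inhibitor in this set; compound 2 sits closest to it, and compound 3 is furthest away, its number beyond the scatter lower than that of compound 1. Compound 2 and compound 3 both carry a 2,6-diisopropylphenyl group on the amide nitrogen, whereas compound 1 carries 2,6-dimethylphenyl there, though the ester side differs as well among them, so no single change separates the measured compounds.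

The unmeasured compound 4, `CC(C)c1cccc(C(C)C)c1OC(=O)CC(=O)Nc1ccccc1`, differs from compound 1 in one place: phenyl in place of 2,6-dimethylphenyl on an amide-type nitrogen. For the measured compounds named here, no measured pair in this set isolates a change of that kind, so the direction has to be judged from the three numbers alone. Within the set, the compounds with the larger group on the amide nitrogen give the lower numbers, and compound 4 moves the other way, to the smaller group. Compound 4 is therefore expected to give a higher number than compound 1, with a step of a 3.8-fold higher number from compound 1 to compound 4 (0.58 log units; beyond the scatter) beyond the scatter. The estimate for compound 4 in this assay is 800 nM, with a range from 250 nM to 2500 nM.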

Compound 4, half-maximal inhibitory concentration: > 5000 nM
Compound 4 ended at the assay's limit (the forecaster's own chance of this, stated with the estimate: 10%); at least 6.2-fold (0.79 log units) between middle value and limit.
By their numbers in this assay, from the lowest: compound 3; then compound 2; then compound 1. At a limit, above all of these: compound 4.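

For the compounds shown here, on an amide-type nitrogen whose other neighbour is the carbonyl carbon, phenyl in place of 2,6-dimethylphenyl is the first single change in this set, and in this assay it gives an at least 23-fold higher number from compound 1 to compound 4 (1.37 log units; beyond the scatter). The earlier compounds shown here differ on the ester side as well as on this nitrogen, so they could only hint at a link between the nitrogen substituent and the number, whereas this pair keeps everything else the same and shows that the two methyl groups of compound 1 matter greatly to inhibition here. Compound 4 stands at a limit of the assay and not at a number, so the real size of the step stays unknown and only its minimum can be read: the limit of > 5000 nM in this assay, at which 1 of the 4 values shown sits.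

The compounds shown leave open how the step divides between the two methyl groups, which a phenyl ring carrying a single methyl group would address, and whether chloro or methoxy groups could stand in for them. They also leave open whether 2,6-diisopropylphenyl on this nitrogen, with the ester side of compound 1 kept, would give a lower number than compound 1 does.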